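Three Amides and a Benzyl Swap

A few compounds are considered here, and "the series" means these few. Any claim that something is new, unique, unknown or untested is made for them only; others in the source may bear on it.

Measured so far:
compound 1 `C=Cc1cccc(C(=O)N2CCCC(C(=O)Nc3ccc(Cl)cc3)C2)c1` gives 0%;
compound 2 `Cc1nc(-c2cccc(NC(=O)C3CCCN(C(=O)c4cc(C(F)(F)F)cc(C(F)(F)F)c4)C3)c2)cs1` gives 1%;
compound 3 `O=C(Nc1cccc(Cc2ccccc2)c1)C1CCCN(C(=O)c2cccc(-c3ccco3)c2)C1` gives 0%.

All three were tested in an ADME assay on PC-3 cells (Homo sapiens) for cytotoxicity, read by WST assay, tested at 100 uM; on this read-out higher numbers stand for more inhibition at the one concentration tested (going by the name of the read-out) and lower numbers for less inhibition. Compound 2 holds the highest of the three numbers, but its nearest neighbour, compound 1, and its furthest, compound 3, each lie only a hair lower, and both gaps fall within the usual scatter of this assay, so nothing separates the three. None of the compounds shows appreciable cytotoxicity at the concentration tested.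

The unmeasured compound 4 `O=C(Nc1cccc(Cc2ccccc2)c1)C1CCCN(C(=O)c2cc(C(F)(F)F)cc(C(F)(F)F)c2)C1` is derived from compound 2 by a single change: benzyl in place of 2-methyl-1,3-thiazol-4-yl on an aromatic carbon. Within the data shown here, no measured pair in this set differs in only one place, so there is no directly comparable step to lean on. Given that compound 2 gives 1% and compound 3, which also carries a benzyl group, gives 0%, the step from compound 2 to compound 4 is expected to be no larger than the scatter, no change at the digits printed from compound 2 to compound 4 (within the scatter). Compound 4 is therefore estimated at 1%, with a range from -6% to 9%.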

Compound 4, a percentage reported as inhibition, at one concentration (the size of the read-out at that concentration, not a potency): 0%
For compound 4 the middle estimate is 1 percentage points above the measured one; low and high end bracket the measured number.
By their numbers in this assay, from the lowest: compounds 1, 3, 4 and 2 (each within the scatter of the next).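

In this assay, among these compounds, the exchange of 2-methyl-1,3-thiazol-4-yl for benzyl on this aromatic carbon, meta to a large group, gives a number 1 percentage points lower from compound 2 to compound 4 (within the scatter) and offers the first direct comparison at this position. A five-membered aromatic ring with 2 hetero atoms and 2 hydrogen-bond acceptors leaves, a six-membered aromatic ring of carbon only and with 0 hydrogen-bond acceptors enters, and the read-out shows no separation between the two compounds. No measurement is at hand that could explain this result.

The compounds shown leave open whether any group at this position can raise the read-out, for instance an amine or a carboxylic acid. From the compounds shown here alone, with a single step at this position, it also remains unknown whether the same exchange would read alike on the core of compound 1.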